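Phenyl in place of methyl on the urea of compound 3

The compounds below may be only part of what the source reports. "The series", "measured", "known", "first", "only" and "open" are said of these compounds alone.

Compound 3 `CNC(=O)NCCCCCCn1c(C)nc(-c2ccccc2)c1-c1ccccc1` ends its chain in a (methylcarbamoyl)amino group. In an assay on H4 cells for inhibition of Fatty-acid amide hydrolase 1 (Homo sapiens) (on this read-out higher numbers stand for weaker inhibition and lower numbers for stronger inhibition), compound 3 gives > 10000 nM, which is a limit of the assay and not a number. Compound 3 shares its core with compound 1 `CCOC(=O)CC(C)CCCCCn1c(C)nc(-c2ccccc2)c1-c1ccccc1` and compound 2 `CCOC(=O)CC(CCCCCn1c(C)nc(-c2ccccc2)c1-c1ccccc1)C(C)C`. In this assay compound 1 gives 130 nM. Compound 2 gives > 100000 nM, again a limit rather than a number. The step of an at least 760-fold higher number from compound 1 to compound 2 (2.88 log units; beyond the scatter) and the step of an at least 76-fold higher number from compound 1 to compound 3 (1.88 log units; beyond the scatter) are both large, while the step that the two limits leave unreadable from compound 2 to compound 3 cannot be read. Compound 3 therefore stands with compound 2 among the limits, the limit of > 10000 nM in this assay, at which 1 of the 3 values shown sits, and (the limit of > 100000 nM in this assay, at which 1 of the 3 values shown sits), and only compound 1 gives a measured number.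

Compound 4 `Cc1nc(-c2ccccc2)c(-c2ccccc2)n1CCCCCCNC(=O)Nc1ccccc1` differs from compound 3 by phenyl in place of methyl on an amide-type nitrogen. Going by the values given here, none of the measured steps touches the urea nitrogen: they concern the branching of the chain and the exchange of the ester end for the urea end, so they bear on this change only in that compound 3 itself is a limit. The account expects the step of an at least 1.2-fold lower number from compound 3 to compound 4 (0.09 log units; that floor lies within the scatter) to be uncertain in both size and direction. Compound 4 is estimated at 8000 nM, within 800 nM to 80000 nM, with a fair chance that only a limit is reported.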

Compound 4, half-maximal inhibitory concentration: 10000 nM
Beside the measured number, compound 4's estimate is 1.3-fold (0.10 log units) below it; the measured number falls inside the stated range.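

Going by these compounds alone, compound 4 gives the first measured number for a chain ending in a urea in this assay, so phenyl in place of methyl on the amide-type nitrogen turns this end of the chain from a limit into a readable result, with a number no higher from compound 3 to compound 4 (the limit leaves the size open). That number can be set against the ester-ended compounds: the (phenylcarbamoyl)amino end shows a 77-fold higher number from compound 1 to compound 4 (1.89 log units; beyond the scatter), while it also shows an at least 10-fold lower number from compound 2 to compound 4 (1.00 log units; beyond the scatter), so compound 4 lies well short of compound 1 yet clear of the limit of compound 2. What phenyl does relative to methyl stays unresolved, and the steps from compound 3 to compound 4 and from compound 2 to compound 3 cannot be read because compound 3 stands at a limit: the limit of > 10000 nM in this assay, at which 1 of the 4 values shown sits.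

The compounds shown leave open whether another group on this nitrogen, such as benzyl or cyclohexyl, would move the urea series closer to compound 1. They also leave open how a carboxylic acid in place of the ethyl ester, or a longer chain carrying the (phenylcarbamoyl)amino end, would read in this assay.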